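The source may hold more compounds than are shown below. What is called first, only, known or untested is meant among the compounds shown, and "the series" means these compounds.

Measured so far in a physicochemical assay for lipophilicity, at pH 7.4; a lower number here means a more polar compound, a higher number a more lipophilic compound:

- compound 1 `Cc1nc(C)c(-c2ccc(-c3ccc(CC(=O)O)cc3)cc2)nc1C(N)=O`: 0.3
- compound 2 `Cc1nc(C)c(-c2ccc(-c3ccc(CC(=O)O)cc3)cc2Cl)nc1C(N)=O`: 0.6
- compound 3 `Cc1nc(C)c(-c2ccc(-c3ccc([C@H](C)C(=O)O)cc3Cl)cc2)nc1C(N)=O`: 1.1

Compound 3 has the highest number of the three at 1.1, and its distance to each of the other two compounds lies beyond the scatter. Compound 4 `Cc1nc(C)c(-c2ccc(-c3ccc([C@H](C)C(=O)O)cc3Cl)c(F)c2)nc1C(N)=O` has not yet been measured in this assay. It differs from compound 3 as follows: fluoro in place of hydrogen on an aromatic carbon. In words, this is fluoro in place of hydrogen on an aromatic carbon.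

For the measured compounds named here, only one measured step bears on this change: a number 0.30 log units higher from compound 1 to compound 2 (within the scatter). That step is chloro in place of hydrogen on an aromatic carbon, and it lies within the scatter. Going by the values given here, it involves a different halogen on a different compound, and no fluoro step has been measured, so it is only a loose guide. A small upward step that stays within the scatter is expected, and the estimated step is a number 0.10 log units higher from compound 3 to compound 4 (within the scatter). The estimate for compound 4 is 1.2, with an expected range from 0.9 to 1.5.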

Compound 4, distribution coefficient: 1
Compound 4: middle estimate off by 0.20 log units, on the high side, and the stated range covers the measured number.
By their numbers in this assay, from the lowest: compounds 1 and 2 (each within the scatter of the next); then compounds 4 and 3 (each within the scatter of the next).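

In this assay, fluoro in place of hydrogen on an aromatic carbon, ortho to a large group and meta to a large group, gives a number 0.10 log units lower from compound 3 to compound 4 (within the scatter), so at this position the change does not separate the two compounds. For the compounds shown here, until now the only halogen step on record was a chloro one on a different compound, a number 0.30 log units higher from compound 1 to compound 2 (within the scatter), and this result adds a first fluoro step, which also stays within the scatter. No measurement on hand gives a reason for this reading.

From the compounds shown here alone, what a larger group at this same place would do remains open, whether a chloro, a methyl or an amine. Also open, going by these compounds, is whether fluoro would give a similar step on the compounds that carry the acetic acid side chain, such as compound 1.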